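Estimating Compound 4 Without a Measured Starting Point

The compounds below may be only part of what the source reports. "The series", "measured", "known", "first", "only" and "open" are said of these compounds alone.

Compound 3 (`CCCCc1nc(C)c(CC(=O)N2CCN(C)CC2)c(=O)n1Cc1ccc(-c2ccccc2-c2nnn[nH]2)cc1`) offers no starting number: in an in vivo functional assay on the whole organism for inhibition, with Rattus norvegicus as the target (on this read-out lower numbers stand for an effect already at smaller amounts and higher numbers for an effect only at larger amounts of compound), compound 3 is recorded as "not determined" (no result reported) and so gives no result. Its relatives compound 1 (`CCCCc1nc(C)c(CC(=O)N2CCCC2)c(=O)n1Cc1ccc(-c2ccccc2-c2nnn[nH]2)cc1`) at 0.056 mg/kg and compound 2 (`CCCCc1nc(C)c(CC(=O)N2CCC[C@H]2C(=O)OC)c(=O)n1Cc1ccc(-c2ccccc2-c2nnn[nH]2)cc1`) at 0.043 mg/kg do carry numbers. Compound 4 (`CCCCc1nc(C)c(CC(=O)N2CC(C)OC(C)C2)c(=O)n1Cc1ccc(-c2ccccc2-c2nnn[nH]2)cc1`) has 2,6-dimethylmorpholin-4-yl in place of 4-methylpiperazin-1-yl on a carbonyl carbon. Within the data shown here, no measured step covers this exchange. The closest is a 1.3-fold lower number from compound 1 to compound 2 (0.11 log units; within the scatter) and it lies within the scatter, though it records a different change. Among the measured compounds shown here, no step of definite size or direction can therefore be expected, and compound 4 should fall near those two values. In this assay the expected value for compound 4 is 0.06 mg/kg with an estimated range from 0.015 mg/kg to 0.25 mg/kg overall.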

Compound 4, dose for half-maximal effect: 0.029 mg/kg
For compound 4 the middle estimate is 2.1-fold (0.32 log units) above the measured one; measured number inside the range.
By their numbers in this assay, from the lowest: compounds 4, 2 and 1 (each within the scatter of the next).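

In this assay, 2,6-dimethylmorpholin-4-yl on the carbonyl carbon gives a 1.5-fold lower number from compound 2 to compound 4 (0.17 log units; within the scatter) and a 1.9-fold lower number from compound 1 to compound 4 (0.29 log units; within the scatter). Numbers at this position previously came only from pyrrolidin-1-yl and 2-(methoxycarbonyl)pyrrolidin-1-yl, so a six-membered non-aromatic ring with 2 hetero atoms now also gives a result that the scatter does not separate from theirs. No supporting data explain this result.

Still open is whether the two methyl groups matter, since plain morpholin-4-yl is not among the compounds shown. From the compounds shown here alone, how a carboxylic acid on this ring would read out also remains unknown.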